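Chloro to methoxy on the longer-chain core

This account rests on a few compounds, and the source may have more. Where it says the series, first, only, none or still open, it means among the compounds named here.

Measured so far:
compound 1, `CCCCCC(CCO)n1cnc2c(Cl)ncnc21`, > 50000 nM
compound 2, `CCCCCC(CCO)n1cnc2c(OC)ncnc21`, > 50000 nM
compound 3, `CCCCCCCCC(CCO)n1cnc2c(Cl)ncnc21`, 1370 nM

In a functional assay on SW480 cells (Homo sapiens) for antiproliferative activity, read by MTT assay, with a stated time of 48 h (on this read-out lower numbers stand for stronger inhibition and higher numbers for weaker inhibition), compound 1 gives > 50000 nM, a limit of the assay. Compound 2 likewise gives > 50000 nM, also a limit. Among the compounds with values here, compound 3 gives 1370 nM, the only number among the three. The step of an at least 36-fold lower number from compound 1 to compound 3 (1.56 log units; beyond the scatter) is propyl in place of hydrogen on a saturated chain carbon, six bonds along the chain from an aromatic nitrogen. The step that the two limits leave unreadable from compound 1 to compound 2 is methoxy in place of chloro on an aromatic carbon; it cannot be read because of the limit of > 50000 nM in this assay, at which 2 of the 3 values shown sit.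

Compound 4, `CCCCCCCCC(CCO)n1cnc2c(OC)ncnc21`, is not yet measured. Its difference from compound 3 is methoxy in place of chloro on an aromatic carbon, the same change as from compound 1 to compound 2, at the same place. The expected step of a 2.2-fold higher number from compound 3 to compound 4 (0.34 log units; beyond the scatter) rests only on compound 3 and its 1370 nM, since the earlier step gives no size. Compound 4 is expected at 3000 nM, between 700 nM and 30000 nM.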

Compound 4, half-maximal inhibitory concentration: 24600 nM
The estimate for compound 4 lay 8.2-fold (0.91 log units) below the measured number; measured number inside the range.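

In this assay, methoxy in place of chloro on the core of compound 3 gives an 18-fold higher number from compound 3 to compound 4 (1.25 log units; beyond the scatter), so on this core the change costs a large part of the inhibition. Propyl in place of hydrogen gives an at least 2.0-fold lower number from compound 2 to compound 4 (0.30 log units; that floor lies within the scatter), and this step can be set beside the earlier one only as a floor: the same change on two cores in this assay, an at least 36-fold lower number (1.56 log units; beyond the scatter) from compound 1 to compound 3 and an at least 2.0-fold lower number (0.30 log units; that floor lies within the scatter) from compound 2 to compound 4; the limit leaves it open whether they differ.

Whether the methoxy change has the same size on the core of compound 1 cannot be read, so its carry-over between cores is neither shown nor excluded, because the steps involving that limit have no measurable size: the limit of > 50000 nM in this assay, at which 2 of the 4 values shown sit.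

The compounds shown leave open how an amine in place of chloro on that aromatic carbon would read. They also leave open whether a longer chain would extend the gain seen with propyl.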